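Carbonyl substituent swap on a shared triazolothiadiazine core

The source may report more compounds than this note shows. Statements on the series, on what has been measured and on what is new or still open speak of the compounds shown alone.

Compound 3 `COc1cc(-c2nnc3n2NC(c2ccco2)C(C(=O)c2ccc(F)cc2)S3)cc(OC)c1OC` carries a 4-fluorophenyl on its carbonyl carbon. In a functional assay on MCF7 cells (Homo sapiens) for cytotoxicity, read by MTT assay, with a stated time of 48 h (on this read-out lower numbers stand for stronger inhibition and higher numbers for weaker inhibition), compound 3 gives > 100000 nM, which is a limit of the assay and not a number. Compound 1 `COc1cc(-c2nnc3n2NC(c2ccco2)C(C(=O)c2ccccc2C)S3)cc(OC)c1OC` gives 69900 nM in this assay. Compound 2 `COc1cc(C(=O)C2Sc3nnc(-c4cc(OC)c(OC)c(OC)c4)n3NC2c2ccco2)cc(OC)c1OC` gives > 100000 nM in this assay, again a limit. The exchange of aryl groups on the carbonyl carbon reads an at least 1.4-fold higher number from compound 1 to compound 2 (0.15 log units; that floor lies within the scatter) and an at least 1.4-fold higher number from compound 1 to compound 3 (0.15 log units; that floor lies within the scatter), while the pair of limits leaves a step that the two limits leave unreadable from compound 2 to compound 3. The set is thus anchored at the limit of > 100000 nM in this assay, at which 2 of the 3 values shown sit, so compound 3 stands at the upper edge of what this assay reports.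

Compound 4 `COc1cc(-c2nnc3n2NC(c2ccco2)C(C(=O)C2CC2)S3)cc(OC)c1OC` differs from compound 3 by cyclopropyl in place of 4-fluorophenyl on a carbonyl carbon. Within the data shown here, none of the measured steps replaces an aryl on the carbonyl carbon with a non-aromatic ring; the three aryl-for-aryl exchanges either sit within the scatter or cannot be read. The step to compound 4 is therefore expected to be a number no higher from compound 3 to compound 4 (the limit leaves the size open), and compound 4 is estimated at 100000 nM, between 30000 nM and 300000 nM, most likely reported only as a limit.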

Compound 4, half-maximal inhibitory concentration: > 100000 nM
Compound 4 ended at the assay's limit; the forecaster's own chance of this, stated with the estimate: 70%; the middle value sits exactly at the limit.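

The cyclopropyl of compound 4 puts a non-aromatic ring on this carbonyl carbon, and in this assay compound 4 gives > 100000 nM, which is a limit of the assay and not a number. Against the 2-methylphenyl, the change reads an at least 1.4-fold higher number from compound 1 to compound 4 (0.15 log units; that floor lies within the scatter), while the steps from compound 2 and from compound 3 to compound 4 cannot be read. Leaving the aryl series for a non-aromatic ring therefore brings no readable strengthening at this position, and only compound 1 keeps a value that is a number: the limit of > 100000 nM in this assay, at which 3 of the 4 values shown sit.

As far as these compounds go, whether an amine or a longer alkyl chain on the carbonyl carbon would bring a value under the limit in this assay stays open. Also open, from the compounds shown here alone, is whether the 2-methylphenyl of compound 1 truly separates from the other groups, since every floor on its steps lies within the scatter.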